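A Dimethoxyphenyl Takes the Place of Dichlorophenyl

A few compounds are considered here, and "the series" means these few. Any claim that something is new, unique, unknown or untested is made for them only; others in the source may bear on it.

Compound 1 `COc1cc(-c2cc(/C=C/C(=O)c3ccc(Cl)c(Cl)c3)[nH]n2)cc(OC)c1OC` was examined in a functional assay on A498 cells (Homo sapiens) for inhibition, read by sulforhodamine B assay, with a stated time of 48 h (a higher number here means that more compound is tolerated, a lower number that less compound is tolerated), where it reached only a limit of the assay: compound 1 gave > 100000 nM. For the measured compounds named here, the shared core is also carried by compound 2 `COc1ccc(-c2cc(/C=C/C(=O)c3ccc(N)cc3)[nH]n2)cc1OC`, which in this assay gave 26200 nM; no single-point step joins these two compounds, so their values are simply set side by side. Compound 3 `COc1ccc(C(=O)/C=C/c2cc(-c3cc(OC)c(OC)c(OC)c3)n[nH]2)cc1OC` has not yet been measured in this assay. It differs from compound 1 by 3,4-dimethoxyphenyl in place of 3,4-dichlorophenyl on a carbonyl carbon. Going by the values given here, all that is known of compound 1 is the limit of > 100000 nM in this assay, at which 1 of the 2 values shown sits, so no measured step exists from which the size of this change could be read. The step from compound 1 to compound 3 is expected to be an at least 1.6-fold lower number from compound 1 to compound 3 (0.22 log units; that floor lies within the scatter), a modest move downward. Compound 3 is accordingly estimated to sit near 60000 nM, within 15000 nM to 150000 nM.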

Compound 3, concentration lethal to 50% of the cells: 6000 nM
Beside the measured number, compound 3's estimate is 10-fold (1.00 log units) above it; measured number outside the range, below it.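

Exchanging the 3,4-dichlorophenyl on a carbonyl carbon for 3,4-dimethoxyphenyl gives an at least 16-fold lower number from compound 1 to compound 3 (1.22 log units; beyond the scatter), so in this assay the group held at this position clearly matters. The earlier compounds shown here could not show this, as no single-point step joined compound 1 to compound 2. Compound 1 gives > 100000 nM, which is a limit of the assay, and the size of the change can be stated only as a floor because one end of the step rests on that limit: the limit of > 100000 nM in this assay, at which 1 of the 3 values shown sits.

From the compounds shown here alone, whether the lower number comes from losing the two chlorine atoms or from gaining the two methoxy groups remains open. Also open, going by these compounds, is how a 4-fluorophenyl or a 3,4-dihydroxyphenyl on the same carbonyl carbon would compare.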